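Series notes: amino in place of nitro at compound 1

The compounds below may be only part of what the source reports. "The series", "measured", "known", "first", "only" and "open" are said of these compounds alone.

compound 1 `O=C1NC(=O)N(/N=C/c2ccc(-c3ccc([N+](=O)[O-])cc3)o2)C1O`: 171 mg/kg
compound 2 `O=C1NC(=O)N(/N=C/c2ccc(-c3ccc(Cl)cc3)o2)C1O`: 63 mg/kg
compound 3 `O=C1NC(=O)N(/N=C/c2ccc(-c3ccc(F)cc3)o2)C1O`: 240 mg/kg

In an ADME assay on the whole organism (muscle tissue) for activation, with Mus musculus as the target, in the rotarod test, with a stated time of 30 min (a higher number here means that more compound is needed for the effect, a lower number that less compound is needed), compound 1 stands second highest of the three numbers. For the measured compounds named here, the only step from it beyond the scatter is a 2.7-fold lower number from compound 1 to compound 2 (0.43 log units; beyond the scatter); the other, a 1.4-fold higher number from compound 1 to compound 3 (0.15 log units; within the scatter), lies within the scatter. Compound 4 `Nc1ccc(-c2ccc(/C=N/N3C(=O)NC(=O)C3O)o2)cc1` differs from compound 1 in one place: amino in place of nitro on an aromatic carbon. Both measured steps concern swaps at this same aromatic carbon, one modest and one within the scatter, and neither involves an amino group, so no direction can be read for this change. The expected step is therefore a 1.0-fold lower number from compound 1 to compound 4 (0.00 log units; within the scatter), none beyond the scatter. For compound 4 the dose in this assay is estimated at 170 mg/kg, with a range from 80 mg/kg to 360 mg/kg.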

Compound 4, dose for half-maximal effect: > 1000 mg/kg
Compound 4: only a limit was reported; the forecaster's own chance of this, stated with the estimate: 5%; at least 5.8-fold (0.76 log units) between middle value and limit.
By their numbers in this assay, from the lowest: compound 2; then compounds 1 and 3 (each within the scatter of the next). At a limit, above all of these: compound 4.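

In this assay compound 4 is known only by a limit, > 1000 mg/kg. At this aromatic carbon, amino stands apart from all three other groups: an at least 5.8-fold higher number from compound 1 to compound 4 (0.76 log units; beyond the scatter), an at least 4.1-fold higher number from compound 3 to compound 4 (0.61 log units; beyond the scatter) and an at least 15-fold higher number from compound 2 to compound 4 (1.20 log units; beyond the scatter). The earlier compounds shown here showed at most modest steps here, whereas this change shows that one swap at this position can produce a large step.

On these data alone, how far compound 4 lies past its limit stays open: the limit of > 1000 mg/kg in this assay, at which 1 of the 4 values shown sits. Whether an acetamido or hydroxyl group at this carbon would follow amino or the other three groups also stays open.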